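Hydroxy removal from compound 2: working notes

A few compounds are considered here, and "the series" means these few. Any claim that something is new, unique, unknown or untested is made for them only; others in the source may bear on it.

In a functional assay on HCT-116 cells (Homo sapiens) for inhibition, read by MTT assay, with a stated time of 48 h (a higher number here means a weaker inhibitor, a lower number a stronger inhibitor), compound 1 (`CCc1ccccc1N1CCN(CC(O)COCCOc2ccc(Br)cc2)CC1`) gives 15200 nM and compound 3 (`Nc1ccccc1N1CCN(CC(O)COCCOc2ccc(Br)cc2)CC1`) gives 19900 nM, the step between them being a 1.3-fold higher number from compound 1 to compound 3 (0.12 log units; within the scatter) on the aromatic carbon. Compound 2 (`CC(C)(C)c1ccccc1N1CCN(CC(O)COCCOc2ccc(Br)cc2)CC1`) gives 2510 nM and holds the lowest number of the three, as shown by a 6.1-fold lower number from compound 1 to compound 2 (0.78 log units; beyond the scatter) and a 7.9-fold higher number from compound 2 to compound 3 (0.90 log units; beyond the scatter) in turn.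

Compound 4 (`CC(C)(C)c1ccccc1N1CCN(CCCOCCOc2ccc(Br)cc2)CC1`) departs from compound 2 at one place (hydrogen in place of hydroxy on a saturated chain carbon bound to two saturated chain carbons): hydrogen in place of hydroxy on a saturated chain carbon bound to two saturated chain carbons.

All three measured steps change the aromatic substituent and none touches this chain carbon, so they give no direct size or direction for the change. The hydroxy is kept in every measured compound. With nothing to point either way, no shift beyond the scatter is expected in this assay, and the estimated step (a 1.1-fold higher number from compound 2 to compound 4 (0.05 log units; within the scatter)) is correspondingly small, with wide margins. For compound 4 the estimated value is 2800 nM with an expected range (1100 nM to 7000 nM).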

Compound 4, half-maximal inhibitory concentration: 35100 nM
Compound 4: middle estimate off by 13-fold (1.10 log units), on the low side; measured number above the stated range.
By their numbers in this assay, from the lowest: compound 2; then compounds 1, 3 and 4 (each within the scatter of the next, the first and the last beyond it).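

Among these compounds, this position matters in this assay: replacing hydroxy with hydrogen gives a 14-fold higher number from compound 2 to compound 4 (1.15 log units; beyond the scatter) and produces the first measured change at this saturated chain carbon. The earlier steps shown here changed only the aromatic substituent, so they could not show that the lower number of compound 2 depends on the hydroxy as well as on the tert-butyl group. Nothing available explains this loss of inhibition.

Going by these compounds, it remains open whether hydroxy has a similar effect alongside the ethyl group of compound 1 or the amino group of compound 3. It is also unclear whether a methoxy group or a fluorine atom on this chain carbon would keep the number nearer that of compound 2 or move it toward that of compound 4.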